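The source may hold more compounds than are shown below. What is called first, only, known or untested is meant among the compounds shown, and "the series" means these compounds.

Two compounds of this series have been run in a functional assay on thoracic aorta (Rattus norvegicus, strain Wistar), with a stated time of 15 min; a higher number here means that more compound is needed for the effect, a lower number that less compound is needed. Compound 1 `CC(NC(=O)NS(=O)(=O)c1ccccc1)c1ccccc1OCc1ccccc1` returns only a limit of the assay, > 200000 nM. Compound 2 `Cc1ccc(S(=O)(=O)NC(=O)NC(C)c2cc(C)ccc2OCc2ccccc2)cc1` gives 91900 nM. Compound 2 thus stands as the only number shown so far. The other value, that of compound 1, is the limit of > 200000 nM in this assay, at which 1 of the 2 values shown sits.

Compound 3 `Cc1ccc(OCc2ccccc2)c(C(C)NC(=O)NS(=O)(=O)c2ccccc2)c1` has not yet been measured in this assay. It differs from compound 2 in one place: hydrogen in place of methyl on an aromatic carbon, so that (4-methylphenyl)sulfonyl becomes phenylsulfonyl. No step between measured compounds is shown for this change. Compound 1 also carries phenylsulfonyl and reports only the limit > 200000 nM. The step from compound 2 to compound 3 is expected to be modest and, if anything, toward more compound needed, a 1.6-fold higher number from compound 2 to compound 3 (0.21 log units; within the scatter). Compound 3 is expected to give about 150000 nM in this assay, within a range of 60000 nM to 400000 nM, with a fair chance that only a limit is reported.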

Compound 3, half-maximal effective concentration: > 200000 nM
Compound 3 ended at the assay's limit (the forecaster's own chance of this, stated with the estimate: 40%); at least 1.3-fold (0.12 log units) between middle value and limit.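

Going by these compounds alone, with hydrogen in place of methyl on an aromatic carbon, 4-methylphenyl becoming phenyl, this assay shows an at least 2.1-fold higher number from compound 2 to compound 3 (0.33 log units; beyond the scatter), the first readable step at this position, and one that lies beyond the scatter. Within the data shown here, compound 2 is now the only compound of the three with a number, so within this small set the 4-methylphenyl group goes with a value inside the range of the assay. The step between compound 1 and compound 3 cannot be read, since both end at a limit, and the series now sits largely at that limit: the limit of > 200000 nM in this assay, at which 2 of the 3 values shown sit.

Going by these compounds, how far compound 3 lies past the limit stays open. Also open, on these data alone, is what a longer chain, a methoxy group, an amine or a carboxylic acid would do in place of this methyl.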